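Swapping the dithiocarbamate amine: from pyridyl to methylpiperazine

The source may hold more compounds than are shown below. What is called first, only, known or untested is meant among the compounds shown, and "the series" means these compounds.

Measured compounds in a functional assay on A-375 cells (Homo sapiens) for antiproliferative activity, read by CCK-8 assay, with a stated time of 72 h, tested at 2 uM; on this read-out higher numbers stand for a stronger effect at the one concentration tested and lower numbers for a weaker effect:
compound 1 `Nc1ccccc1NC(=O)c1ccc(CSC(=S)N2CCN(c3ccc(Cl)cc3)CC2)cc1` gives 32.2%
compound 2 `CN(Cc1cccnc1)C(=S)SCc1ccc(C(=O)Nc2ccccc2N)cc1` gives 39.4%
compound 3 `CN(C(=S)SCc1ccc(C(=O)Nc2ccccc2N)cc1)c1cccnc1` gives 26.5%

Compound 3 has the lowest of the three numbers. Going by the values given here, its gap to compound 1 lies within the scatter, while the one measured step, a number 12.9 percentage points lower from compound 2 to compound 3 (beyond the scatter), is beyond it. Compound 4 `CN1CCN(C(=S)SCc2ccc(C(=O)Nc3ccccc3N)cc2)CC1` differs from compound 3 by 4-methylpiperazin-1-yl in place of methyl(pyridin-3-yl)amino on a thiocarbonyl carbon. Among the compounds with values here, no measured step changes the amine on the thiocarbonyl carbon in this way, so the step from compound 2 to compound 3 bears only loosely on it. Compound 1, which also carries a piperazine on that carbon, and compound 3 show values within the scatter of each other. The step of a number 3.5 percentage points higher from compound 3 to compound 4 (within the scatter) is therefore expected to be small. Compound 4 is estimated at 30%, within 15% to 45%.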

Compound 4, a percentage reported as inhibition, at one concentration (the size of the read-out at that concentration, not a potency): 36.6%
For compound 4 the middle estimate is 6.6 percentage points below the measured one; measured number inside the range.
By their numbers in this assay, from the lowest: compounds 3, 1, 4 and 2 (each within the scatter of the next, the first and the last beyond it).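

Replacing methyl(pyridin-3-yl)amino with 4-methylpiperazin-1-yl on the thiocarbonyl carbon gives a number 10.1 percentage points higher from compound 3 to compound 4 (beyond the scatter) in this assay and so shows that this position responds to the choice of amine. An aromatic ring in the amine does not settle the number on its own, as compound 2 also carries one and the change gives a number 2.8 percentage points lower from compound 2 to compound 4 (within the scatter) here. Methyl in place of 4-chlorophenyl on the piperazine amine nitrogen gives a number 4.4 percentage points higher from compound 1 to compound 4 (within the scatter) and so shows no clear effect of that swap.

On these data alone, whether morpholine or piperidine on the thiocarbonyl carbon would fit with these numbers remains open. Nothing shown gives a reason for these steps.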